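Trimethoxybenzyl in place of methyl on a piperazine nitrogen

A few compounds are considered here, and "the series" means these few. Any claim that something is new, unique, unknown or untested is made for them only; others in the source may bear on it.

Measured compounds:
compound 1, `CN1CCN(c2nc(Nc3ccc(C#N)c(C(F)(F)F)c3)nc(Oc3ccnc4ccccc34)n2)CC1`, a functional assay on DU-145 cells (Homo sapiens) for cytotoxicity, read by sulforhodamine B assay, with a stated time of 48 h; a lower number here means that less compound is tolerated, a higher number that more compound is tolerated: > 100000 nM
compound 2, `N#Cc1ccc(Nc2nc(Oc3ccnc4ccccc34)nc(N3CCN(c4cccc(C(F)(F)F)c4)CC3)n2)cc1C(F)(F)F`, this assay: > 100000 nM
compound 3, `CCN1CCN(c2nc(Nc3ccc(C#N)c(C(F)(F)F)c3)nc(Oc3ccnc4ccccc34)n2)CC1`, this assay: > 100000 nM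

In this assay compound 3 gives only a limit, > 100000 nM. Compound 1 likewise gives only a limit in this assay. Compound 2 gives only a limit in this assay as well. All three values therefore sit at the limit of > 100000 nM in this assay, at which 3 of the 3 values shown sit, and none of the steps among them can be sized: a step that the two limits leave unreadable from compound 1 to compound 2, a step that the two limits leave unreadable from compound 1 to compound 3 and a step that the two limits leave unreadable from compound 2 to compound 3 are all unreadable.

Compound 4, `COc1ccc(CN2CCN(c3nc(Nc4ccc(C#N)c(C(F)(F)F)c4)nc(Oc4ccnc5ccccc45)n3)CC2)c(OC)c1OC`, differs from compound 3 by 2,3,4-trimethoxyphenyl in place of methyl on a saturated chain carbon bound to an amine nitrogen in a ring. The measured steps bear on this change only loosely: they show that exchanging a methyl, an ethyl or a 3-(trifluoromethyl)phenyl on that amine nitrogen in a ring leaves every compound at the limit, but none of them reads a size. The 2,3,4-trimethoxyphenyl on the saturated chain carbon is a larger change than any measured, so compound 4 is expected to sit near the limit again, with a number no higher from compound 3 to compound 4 (the limit leaves the size open) expected to be small or unreadable. The estimate for compound 4 in this assay is 100000 nM, with a range from 20000 nM to 300000 nM.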

Compound 4, concentration lethal to 50% of the cells: > 100000 nM
Compound 4 was reported as a limit (the forecaster's own chance of this, stated with the estimate: 65%); the middle value sits exactly at the limit.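

Compound 4, like compound 1 and compound 3, is reported in this assay only as a limit, so no step to compound 4 can be read: the limit of > 100000 nM in this assay, at which 4 of the 4 values shown sit.

The compounds shown leave open the actual lethal concentration of each, and so whether exchanging the group on the amine nitrogen in a ring makes any difference.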